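The compounds below may be only part of what the source reports. "The series", "measured", "known", "first", "only" and "open" are said of these compounds alone.

Measured compounds:
- compound 1 `CC(C)C1(COC(=O)Nc2ccc(F)cc2)OC(=O)Nc2ccc(Cl)cc21`: 5030 nM
- compound 2 `O=C(Nc1ccc(F)cc1)OCC1(C2CC2)OC(=O)Nc2ccc(Cl)cc21`: 1410 nM

In an assay for inhibition of very long chain fatty acid elongase 6 (Homo sapiens) (on this read-out lower numbers stand for stronger inhibition and higher numbers for weaker inhibition), compound 1 gives 5030 nM and compound 2 gives 1410 nM, so compound 2 stands lower of the two numbers, the only other one being that of compound 1. Among the compounds with values here, the single measured step is a 3.6-fold lower number from compound 1 to compound 2 (0.55 log units; beyond the scatter), a shift that lies beyond the scatter and was brought by exchanging one small saturated group for another on the shared core.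

Compound 3 `O=C(Nc1ccc(F)cc1)OCC1(c2ccccc2)OC(=O)Nc2ccc(Cl)cc21` differs from compound 2 by phenyl in place of cyclopropyl on a saturated ring carbon. Within the data shown here, no measured pair shows an aromatic ring in this position, so the step from compound 1 to compound 2 bears on it only loosely: it shows that this position tolerates change in this assay and that a change there can move the number by a modest amount. Whether a phenyl follows the direction of the cyclopropyl cannot be read from the two numbers.

Compound 3 is therefore estimated at 1000 nM in this assay, with a range from 250 nM to 4000 nM. The expected step is a 1.4-fold lower number from compound 2 to compound 3 (0.15 log units; within the scatter), which stays within the scatter.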

Compound 3, half-maximal inhibitory concentration: > 10000 nM
Compound 3: no number, only a limit; the forecaster's own chance of this, stated with the estimate: 5%; middle value at least 10-fold (1.00 log units) from the limit.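

In this assay compound 3 stands only as a limit of the assay, not as a number: the limit of > 10000 nM in this assay, at which 1 of the 3 values shown sits.

Even so, the limit gives an at least 7.0-fold higher number from compound 2 to compound 3 (0.85 log units; beyond the scatter), so this saturated ring carbon, next to the ring oxygen, does not take every group alike: the earlier pair showed only a modest shift between isopropyl and cyclopropyl, whereas phenyl in place of cyclopropyl gives up at least the ground printed here. Set against isopropyl, the same limit gives an at least 1.9-fold higher number from compound 1 to compound 3 (0.29 log units; that floor lies within the scatter), so on this floor alone compound 3 cannot be firmly separated from compound 1, and the clear loss is the one measured from the cyclopropyl of compound 2.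

As far as these compounds go, how far the number of compound 3 lies past the limit stays open, and so does the size of the true step from either neighbour. Also open, from the compounds shown here alone, is whether the loss goes with the aromatic ring or with the six ring carbons of the phenyl, a question on which a cyclohexyl or a pyridyl at this same carbon would bear.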